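A few compounds are considered here, and "the series" means these few. Any claim that something is new, unique, unknown or untested is made for them only; others in the source may bear on it.

The measured compounds:
Compound 1, `COc1cc(N/C=C\C(=O)c2cn(-c3ccccc3)nc2-c2ccc(F)cc2)cc(OC)c1OC`: in a functional assay on HT-29 cells (Homo sapiens) for antiproliferative activity, read by MTT assay, with a stated time of 48 h (on this read-out lower numbers stand for stronger inhibition and higher numbers for weaker inhibition), compound 1 gives 7770 nM.
Compound 2, `COc1cc(-c2nn(-c3ccccc3)cc2C(=O)/C=C\Nc2ccc(O)cc2)cc(OC)c1OC`: in this assay compound 2 gives 2500 nM.

Compound 2 holds the lowest of the two numbers; the nearest is compound 1, whose number lies higher by a margin beyond the usual scatter. The two differ in more than one place, so only their two values can be set side by side. Compound 3, `COc1cc(N/C=C\C(=O)c2cn(-c3ccccc3)nc2-c2cc(OC)c(OC)c(OC)c2)cc(OC)c1OC`, differs from compound 2 in one place: 3,4,5-trimethoxyphenyl in place of 4-hydroxyphenyl on an amine nitrogen. Among the compounds with values here, no measured pair shows this change on its own. Compound 1 also carries a 3,4,5-trimethoxyphenyl group on its amine nitrogen and sits at 7770 nM, yet it differs elsewhere too, so that reading is weak. A modest step toward a higher number, near the edge of the scatter, is expected from compound 2 to compound 3, a 1.8-fold higher number from compound 2 to compound 3 (0.26 log units; within the scatter). Compound 3 is therefore estimated at 4500 nM in this assay, with a range from 1500 nM to 14000 nM.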

Compound 3, half-maximal inhibitory concentration: 8400 nM
The estimate for compound 3 lay 1.9-fold (0.27 log units) below the measured number, and the stated range covers the measured number.
By their numbers in this assay, from the lowest: compound 2; then compounds 1 and 3 (each within the scatter of the next).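

On the amine nitrogen, 3,4,5-trimethoxyphenyl in place of 4-hydroxyphenyl now has a direct reading in this assay, with a 3.4-fold higher number from compound 2 to compound 3 (0.53 log units; beyond the scatter), so the 4-hydroxyphenyl group goes with the lower number in this pair. On an aromatic carbon, 3,4,5-trimethoxyphenyl in place of 4-fluorophenyl gives a 1.1-fold higher number from compound 1 to compound 3 (0.03 log units; within the scatter), so this change shows no separable effect in this assay. Nothing at hand gives a cause for either step.

Going by these compounds, whether a plain phenyl or a 4-aminophenyl group on the amine nitrogen would stand closer to compound 2 or to compound 3 remains open. On these data alone, it is also open whether the step seen on the amine nitrogen would hold with 4-fluorophenyl on the aromatic carbon.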